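Trifluoromethyl on the aryl ring of compound 2

The compounds below may be only part of what the source reports. "The series", "measured", "known", "first", "only" and "open" are said of these compounds alone.

Compound 2 `O=C(O)Cc1sc(C(c2ccccc2)c2ccccc2)nc1-c1ccccc1` is a thiazole acetic acid carrying an unsubstituted phenyl and a diphenylmethyl group. In an in vitro assay on HEK385-7 cells for displacement of a labelled ligand from prostaglandin D2 receptor 2 (Homo sapiens) (a higher number here means a weaker inhibitor, a lower number a stronger inhibitor), compound 2 gives 570 nM, the highest number among the three measured compounds. Compound 3 `CCC(c1ccccc1)c1nc(-c2ccc(Cl)cc2)c(CC(=O)O)s1` gives 190 nM in this assay, and compound 1 `N#Cc1cc(-c2nc(C(c3ccc(F)cc3)c3ccc(F)cc3)sc2CC(=O)O)ccc1F` gives 57 nM in this assay; both of these carry substituents on their aryl rings where compound 2 carries hydrogen, and both lie beyond the scatter from compound 2.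

Compound 4 `O=C(O)Cc1sc(C(c2ccccc2)c2ccccc2)nc1-c1ccc(C(F)(F)F)cc1` differs from compound 2 in one place: trifluoromethyl in place of hydrogen on an aromatic carbon. Among the measured compounds shown here, no measured pair shows exactly this change, so its size is a matter of expectation. The two substituted analogues, compound 3 and compound 1, both give lower numbers than compound 2, which suggests that a substituent on this ring tends to go with a stronger inhibitor. Compound 4 is therefore expected to give a lower number than compound 2 in this assay, with an estimated step of a 2.9-fold lower number from compound 2 to compound 4 (0.45 log units; beyond the scatter). The estimate for compound 4 is 200 nM, with a range from 70 nM to 600 nM.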

Compound 4, half-maximal inhibitory concentration: 1100 nM
Compound 4: middle estimate off by 5.5-fold (0.74 log units), on the low side; measured number above the stated range.
By their numbers in this assay, from the lowest: compound 1; then compound 3; then compounds 2 and 4 (each within the scatter of the next).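

Among the compounds shown here, compound 2 and compound 4 are the first pair here that differ in one place: trifluoromethyl in place of hydrogen on an aromatic carbon, para to a large group, gives a 1.9-fold higher number from compound 2 to compound 4 (0.29 log units; within the scatter) in this assay. A substituent at this position therefore does not by itself bring a stronger inhibitor, since this one, with its four heavy atoms, leaves the number within the scatter of the plain phenyl. Nothing measured here explains this result.

Compound 1 and compound 3 each differ from compound 2 in more than one place, so they cannot show what a substituent on this ring does alone. Going by these compounds, whether a methoxy group or an amine at this same position would move the number beyond the scatter remains open.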